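A few compounds are considered here, and "the series" means these few. Any claim that something is new, unique, unknown or untested is made for them only; others in the source may bear on it.

Working notes on the series. Compound 1 `COc1ccc(OC)c(/C=N/NC(=O)Nc2ccc(Oc3ccnc(-c4nncn4CCN(C)C)c3)c(F)c2)c1` is measured in a functional assay on A549 cells (Homo sapiens) for cytotoxicity, read by MTT assay, with a stated time of 72 h (a lower number here means a stronger inhibitor, a higher number a weaker inhibitor), where compound 1 gives 1950 nM. Compound 3 `Cc1cc(/C=N/NC(=O)Nc2ccc(Oc3ccnc(-c4nncn4CCN(C)C)c3)c(F)c2)cc(C)c1O` gives 1640 nM in this assay, and the step of a 1.2-fold lower number from compound 1 to compound 3 (0.08 log units; within the scatter), so the two numbers are indistinguishable. Compound 2 `CN(C)CCn1cnnc1-c1cc(Oc2ccc(NC(=O)N/N=C/c3cc(Br)c(O)c(Br)c3)cc2F)ccn1` reaches only the limit of this assay, recorded for compound 2 as > 100000 nM, which is the limit of > 100000 nM in this assay, at which 1 of the 3 values shown sits. Among the three, compound 1 and compound 3 sit together within the scatter, and compound 2 gives a limit rather than a number. The step of an at least 51-fold higher number from compound 1 to compound 2 (1.70 log units; beyond the scatter), and the step of an at least 60-fold lower number from compound 2 to compound 3 (1.78 log units; beyond the scatter), so the aryl on the carbon with a double bond to nitrogen can move this series across its whole measured span.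

Compound 4 `COc1ccc(/C=N/NC(=O)Nc2ccc(Oc3ccnc(-c4nncn4CCN(C)C)c3)c(F)c2)c(OC)c1OC` differs from compound 1 by 2,3,4-trimethoxyphenyl in place of 2,5-dimethoxyphenyl on a carbon with a double bond to nitrogen. All three measured steps concern this same position. The exchange to a hydroxy aryl bearing methyls (a 1.2-fold lower number from compound 1 to compound 3 (0.08 log units; within the scatter)) left the number within the scatter, whereas the dibromo hydroxy aryl (an at least 51-fold higher number from compound 1 to compound 2 (1.70 log units; beyond the scatter)) moved the compound to the limit. Compound 4 keeps methoxy groups only, adding one more, and so resembles compound 1 far more than compound 2. The step expected is therefore a 1.0-fold higher number from compound 1 to compound 4 (0.01 log units; within the scatter), within the scatter. Compound 4 is estimated at 2000 nM, with a range from 800 nM to 5500 nM.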

Compound 4, half-maximal inhibitory concentration: 6680 nM
Compound 4: middle estimate off by 3.3-fold (0.52 log units), on the low side; the whole stated range lies below it.
By their numbers in this assay, from the lowest: compounds 3 and 1 (each within the scatter of the next); then compound 4. At a limit, above all of these: compound 2.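

In this assay, the exchange on the carbon with a double bond to nitrogen gives a 3.4-fold higher number from compound 1 to compound 4 (0.53 log units; beyond the scatter), so this place also responds to a change between two aryls that carry only methoxy groups, which compounds 1 to 3 could not show. Against the hydroxy aryl bearing methyls the result is also modest, with a 4.1-fold higher number from compound 3 to compound 4 (0.61 log units; beyond the scatter), while an at least 14-fold lower number from compound 2 to compound 4 (1.17 log units; beyond the scatter) shows that compound 4 stays far from the outcome of the dibromo hydroxy aryl, so the measured aryls now fall at three levels rather than two. Compound 2 remains a limit of the assay and not a number: the limit of > 100000 nM in this assay, at which 1 of the 4 values shown sits.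

The compounds shown do not separate the added methoxy group from the changed arrangement of the methoxy groups, since 2,3,4-trimethoxyphenyl differs from 2,5-dimethoxyphenyl in both respects. Also open, from the compounds shown here alone, is how this place would read with a non-aryl group or with an aryl carrying an amine or a carboxylic acid, and whether the bromine atoms of compound 2 alone account for its limit.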